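Swapping an Amine Side Chain on a Chlorinated Salicylanilide

The source may report more compounds than this note shows. Statements on the series, on what has been measured and on what is new or still open speak of the compounds shown alone.

Measured compounds:
compound 1 `O=C(Nc1ccc(NCC2CC2)cc1Cl)c1cc(Cl)ccc1O` – 14400 nM
compound 2 `O=C(Nc1ccc(NCc2cc(Cl)cc(C(F)(F)F)c2)cc1Cl)c1cc(Cl)ccc1O` – 30900 nM

In an ADME assay on A549 cells (Homo sapiens) for cytotoxicity, read by resazurin assay, with a stated time of 48 h (on this read-out lower numbers stand for higher toxicity in this test and higher numbers for lower toxicity in this test), compound 1 gives 14400 nM, the lower of the two numbers shown. Compound 2 gives 30900 nM, a higher number that lies beyond the scatter of repeated measurements.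

Compound 3 `O=C(Nc1ccc(N(CCCO)CCCO)cc1Cl)c1cc(Cl)ccc1O` differs from compound 1 in one place: bis(3-hydroxypropyl)amino in place of (cyclopropylmethyl)amino on an aromatic carbon. Among the compounds with values here, no measured pair shows this kind of change, so the step in this assay is uncertain. A moderate rise in the number is expected, which would mean an estimated step of a 1.7-fold higher number from compound 1 to compound 3 (0.24 log units; within the scatter). For compound 3 the expected value is 25000 nM, within a range of 8000 nM to 80000 nM.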

Compound 3, half-maximal cytotoxic concentration: 114000 nM
Estimate against measurement, compound 3: 4.6-fold (0.66 log units) below; the measured number lies above the stated range.
By their numbers in this assay, from the lowest: compound 1; then compound 2; then compound 3.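

In this assay, bis(3-hydroxypropyl)amino in place of (cyclopropylmethyl)amino gives a 7.9-fold higher number from compound 1 to compound 3 (0.90 log units; beyond the scatter). This single change therefore moves the number well beyond the scatter, towards lower toxicity in this test, and the side chain on this aromatic carbon clearly matters. No measurement here explains why the number rises so far.

The entering group differs in several ways at once: it has no ring, and it has two chains ending in oxygen. The compounds shown leave open whether a single 3-hydroxypropylamino group or a bis(3-methoxypropyl)amino group would give a similar number.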